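From methyl to phenyl on the shared core

The source may hold more compounds than are shown below. What is called first, only, known or untested is meant among the compounds shown, and "the series" means these compounds.

Measured so far in a physicochemical assay for solubility, in phosphate buffer, with a stated time of 18 h, at pH 7.4; on this read-out lower numbers stand for lower solubility and higher numbers for higher solubility:
- compound 1 `CCOC(=O)CNc1nc(-n2nc(-c3ccccn3)nc2N)c2cc(OC)c(OC)cc2n1` gives 48000 nM
- compound 2 `COc1cc2nc(C)nc(-n3nc(-c4ccccn4)nc3N)c2cc1OC` gives 16000 nM

Of these two numbers, compound 2 holds the lower, and compound 1 is the nearest and only other value. The next structure, compound 3 `COc1cc2nc(-c3ccccc3)nc(-n3nc(-c4ccccn4)nc3N)c2cc1OC`, has phenyl in place of methyl on an aromatic carbon. Within the data shown here, only one measured step bears on this change, and it involves the same aromatic carbon: a 3.0-fold lower number from compound 1 to compound 2 (0.48 log units; beyond the scatter). That step was modest but beyond the scatter. It does not test a phenyl group, so it offers only a rough guide to size. A step of similar size towards a lower number is expected, though with wide uncertainty. The expected step is a 3.2-fold lower number from compound 2 to compound 3 (0.51 log units; beyond the scatter). For compound 3 the estimate is 5000 nM, with an expected range from 1500 nM to 15000 nM.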

Compound 3, solubility: 2000 nM
Estimate against measurement, compound 3: 2.5-fold (0.40 log units) above, and the stated range covers the measured number.
By their numbers in this assay, from the lowest: compound 3; then compound 2; then compound 1.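

At this aromatic carbon, between two ring nitrogen atoms, this assay now shows a second replacement moving the same way as the first, with an 8.0-fold lower number from compound 2 to compound 3 (0.90 log units; beyond the scatter). Taken across the three groups, the change reaches a 24-fold lower number from compound 1 to compound 3 (1.38 log units; beyond the scatter), the only large step shown, so the number at this one position can span a wide range while the rest of the shared core stays the same. Nothing measured here accounts for the size of either step.

Three groups cannot separate the contribution of the added aromatic ring from that of the added heavy atoms. On these data alone, it remains open where a pyridyl ring, a morpholine or a carboxylic acid in place of the ethyl ester would fall relative to these compounds.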